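A few compounds are considered here, and "the series" means these few. Any claim that something is new, unique, unknown or untested is made for them only; others in the source may bear on it.

Measured in a functional assay on HT cells (Homo sapiens) for antiproliferative activity, read by fluorescence, with a stated time of 72 h; a higher number here means a weaker inhibitor of growth, a lower number a stronger inhibitor of growth:

compound 1 `CSc1nc(NCc2ccc(-c3ccccn3)cc2)c2[nH]nc(C(C)C)c2n1`: 783 nM
compound 2 `CC(C)c1n[nH]c2c(NCc3ccc(-c4ccccn4)cc3)nc(SCC(O)CO)nc12`: 21 nM
compound 3 `CC(C)c1n[nH]c2c(NCc3ccc(-c4ccccn4)cc3)nc(S)nc12`: 2760 nM

Compound 1 stands second highest of these three numbers. Its nearest neighbour is compound 3, reached by a 3.5-fold higher number from compound 1 to compound 3 (0.55 log units; beyond the scatter); its furthest is compound 2, reached by a 37-fold lower number from compound 1 to compound 2 (1.57 log units; beyond the scatter). The step to compound 4 `CCC(CO)Sc1nc(NCc2ccc(-c3ccccn3)cc2)c2[nH]nc(C(C)C)c2n1` is 1-(hydroxymethyl)propyl in place of methyl on a sulfur.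

Among the measured compounds shown here, the steps that bear on this both concern the chain on the sulfur. Building out from the methyl of compound 1 to the 2,3-dihydroxypropyl of compound 2 gave a 37-fold lower number from compound 1 to compound 2 (1.57 log units; beyond the scatter), and stripping that chain down to hydrogen gave a 130-fold higher number from compound 2 to compound 3 (2.12 log units; beyond the scatter). A hydroxylated chain on the sulfur thus goes with a much lower number. Compound 4 carries a 1-(hydroxymethyl)propyl, a hydroxylated chain of roughly the size seen in compound 2, so a downward step is expected, though perhaps not the full size of a 37-fold lower number from compound 1 to compound 2 (1.57 log units; beyond the scatter): a 9.8-fold lower number from compound 1 to compound 4 (0.99 log units; beyond the scatter). Compound 4 is estimated at 80 nM, expected to lie between 25 nM and 300 nM.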

Compound 4, concentration for 50% growth inhibition: 255 nM
For compound 4 the middle estimate is 3.2-fold (0.50 log units) below the measured one; the range from low to high includes it.
By their numbers in this assay, from the lowest: compound 2; then compound 4; then compound 1; then compound 3.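

In this assay the 1-(hydroxymethyl)propyl chain on the sulfur gives a 3.1-fold lower number from compound 1 to compound 4 (0.49 log units; beyond the scatter) and an 11-fold lower number from compound 3 to compound 4 (1.03 log units; beyond the scatter) but replacing the 2,3-dihydroxypropyl chain with it gives a 12-fold higher number from compound 2 to compound 4 (1.08 log units; beyond the scatter) at this same place. A hydroxylated chain on the sulfur is therefore not enough on its own to reach the low number of compound 2: the result depends on which such chain sits there. Nothing measured here explains the gap between these two chains.

The two chains differ in their branching and in their hydroxyl groups together, so the compounds shown cannot separate these features. Going by these compounds, it also remains open how an unbranched 2-hydroxyethyl chain, a plain propyl chain, or a chain ending in an amine or a carboxylic acid would compare.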